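This account rests on a few compounds, and the source may have more. Where it says the series, first, only, none or still open, it means among the compounds named here.

Measured so far in an assay on NIH3T3 cells with Urotensin-2 receptor (Homo sapiens) as the target; on this read-out lower numbers stand for smaller maximal responses and higher numbers for larger maximal responses:
Compound 1, `Cc1cccc(C(=O)OC(CCN(C)C)c2ccc(Cl)cc2)c1C`: 91%
Compound 2, `Cc1ccccc1C(=O)NC(CCN(C)C)c1ccc(Cl)cc1`: 175%

Within the data shown here, only these two compounds have been measured, and they differ in more than one place, so no single structural step between measured compounds can be read from them. In this assay compound 1 gives 91%, while compound 2 gives 175%. Compound 2 thus stands highest of the two numbers, and the gap to compound 1 lies beyond the usual scatter of repeated measurements, so compound 2 reaches the larger maximal response of the pair.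

The next compound, compound 3 `Cc1ccccc1NC(=O)NC(CCN(C)C)c1ccc(Cl)cc1`, has not yet been measured. It differs from compound 2 in one place: (2-methylphenyl)amino in place of 2-methylphenyl on a carbonyl carbon. Among the measured compounds shown here, no measured step of this kind exists here. The expectation rests only on the two values shown. Starting from the high value of compound 2, the expected step in this assay is a number 45 percentage points lower from compound 2 to compound 3 (beyond the scatter), a downward move somewhat beyond the scatter, though with wide uncertainty. Compound 3 is therefore estimated at 130%, with a range from 70% to 190%.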

Compound 3, largest response reached (reported as efficacy), in percent of the reference or control that the assay uses: 175%
For compound 3 the middle estimate is 45 percentage points below the measured one; low and high end bracket the measured number.
By their numbers in this assay, from the lowest: compound 1; then compounds 2 and 3 (each within the scatter of the next).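

In this assay, putting (2-methylphenyl)amino in place of 2-methylphenyl on the carbonyl carbon gives no change at the digits printed from compound 2 to compound 3 (within the scatter). The entering group brings a nitrogen and a hydrogen-bond donor that the leaving group lacks, and it is also slightly larger, yet the maximal response holds, so the high value of compound 2 does not depend on having the aromatic ring attached directly to the carbonyl carbon. No measurement shown here gives a reason for this result.

The compounds leave open whether the nitrogen itself matters at this place, or whether another link would serve equally well, as in a 2-methylphenoxy group with oxygen in place of the nitrogen or a 2-methylbenzyl group with a carbon there. Also open, on these data alone, is how much the aromatic ring and its methyl group contribute, since compound 2 and compound 3 both carry them, and a simple amine such as dimethylamino or a cyclohexylamino group on the same carbonyl carbon would test that directly.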